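Side-Chain Variation on a Shared Core

This account rests on a few compounds, and the source may have more. Where it says the series, first, only, none or still open, it means among the compounds named here.

Compound 1 `Cc1ncc([N+](=O)[O-])n1CCOC(=O)c1cc(NC(=O)[C@H](C)NC(=O)OCc2ccccc2)ccc1O` and compound 2 `Cc1ncc([N+](=O)[O-])n1CCOC(=O)c1cc(NC(=O)[C@H](CCCCN)NC(=O)OCc2ccccc2)ccc1O` share the same core and differ only in the group carried on a saturated chain carbon. In a functional assay on the whole organism (strain Wistar) for inhibition, with Rattus norvegicus as the target, read by paw edema, with stated times of 1 h and 2 h, at a dose of 10 mg/kg by the intraperitoneal route (on this read-out lower numbers stand for less inhibition and higher numbers for more inhibition at the one dose given (going by the name of the read-out)), compound 1 gives 37.5% and compound 2 gives 37.8%. The step of a number 0.3 percentage points higher from compound 1 to compound 2 (within the scatter) is thus within the scatter, so although compound 2 has the top of the two numbers shown, no real separation from compound 1 can be claimed. Compound 3 `Cc1ncc([N+](=O)[O-])n1CCOC(=O)c1cc(NC(=O)[C@@H](NC(=O)OCc2ccccc2)C(C)C)ccc1O` has not yet been measured in this assay. It differs from compound 2 by isopropyl in place of 4-aminobutyl on a saturated chain carbon bound to an amide-type nitrogen and a carbonyl carbon. Among the measured compounds shown here, the only step that bears on this position, a number 0.3 percentage points higher from compound 1 to compound 2 (within the scatter), showed no shift beyond the scatter, so the step of a number 0.8 percentage points lower from compound 2 to compound 3 (within the scatter) is likewise expected to stay within the scatter, with no particular direction. Compound 3 is therefore estimated to give 37% in this assay, with a range from 26% to 48%.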

Compound 3, a percentage reported as inhibition, in the whole organism at one dose (the size of the read-out at that dose, not a potency): 64.5%
Beside the measured number, compound 3's estimate is 27.5 percentage points below it; measured number above the stated range.
By their numbers in this assay, from the lowest: compounds 1 and 2 (each within the scatter of the next); then compound 3.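

In this assay, the saturated chain carbon bound to an amide-type nitrogen and a carbonyl carbon proves sensitive to its group after all, which compound 1 and compound 2 alone did not reveal. Isopropyl in place of 4-aminobutyl gives a number 26.7 percentage points higher from compound 2 to compound 3 (beyond the scatter), and isopropyl in place of methyl gives a number 27 percentage points higher from compound 1 to compound 3 (beyond the scatter), so among these three groups isopropyl alone stands apart, while methyl and 4-aminobutyl remain within the scatter of each other. Nothing available here accounts for this difference.

The compounds shown leave open whether the branched shape of isopropyl matters, which an unbranched propyl chain or a tert-butyl group on the same carbon would test. They also leave open how a carboxylic acid or a benzyl group at this place would read out.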